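Replacing the aryl group: from nitrophenyl to chlorophenyl

The source may hold more compounds than are shown below. What is called first, only, known or untested is meant among the compounds shown, and "the series" means these compounds.

Two compounds have been measured in a functional assay on Ehrlich cells (Mus musculus) for cytotoxicity, read by trypan blue exclusion, with a stated time of 2 h, tested at 100 ug/mL; a lower number here means a weaker effect, a higher number a stronger effect of the compound at the concentration tested:

compound 1, `N#CC1=C(N)N(c2ccc(S(N)(=O)=O)cc2)C2=C(CCCC2)C1c1ccc(O)cc1`, gives 100%
compound 2, `N#CC1=C(N)N(c2ccc(S(N)(=O)=O)cc2)C2=C(CCCC2)C1c1ccc([N+](=O)[O-])cc1`, gives 20%

Compound 2 stands at the lowest of the two numbers in this assay; its nearest neighbour is compound 1, which lies far higher. For the measured compounds named here, the single measured step, a number 80 percentage points lower from compound 1 to compound 2 (beyond the scatter), concerns the hydroxy-to-nitro exchange on the aromatic carbon and is large.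

Compound 3, `N#CC1=C(N)N(c2ccc(S(N)(=O)=O)cc2)C2=C(CCCC2)C1c1ccccc1Cl`, has not yet been measured. It differs from compound 2 as follows: 2-chlorophenyl in place of 4-nitrophenyl on a saturated ring carbon. Going by the values given here, no measured step involves a 2-chlorophenyl group, and the one known step, a number 80 percentage points lower from compound 1 to compound 2 (beyond the scatter), removes the hydroxy that compound 3 also lacks, so it bears on the question only loosely. Compound 3 is therefore expected to lie somewhere between the two known values, with a broad range, estimated at 50% (15% to 95%), a step of a number 30 percentage points higher from compound 2 to compound 3 (beyond the scatter) in this assay.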

Compound 3, a percentage reported as activity, at one concentration (the size of the read-out at that concentration, not a potency): 10%
Compound 3: middle estimate off by 40 percentage points, on the high side; the whole stated range lies above it.
By their numbers in this assay, from the lowest: compounds 3 and 2 (each within the scatter of the next); then compound 1.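

Exchanging 4-nitrophenyl for 2-chlorophenyl on the saturated ring carbon in this assay gives a number 10 percentage points lower from compound 2 to compound 3 (within the scatter), so these two aryl groups cannot be told apart here. Placing 2-chlorophenyl where 4-hydroxyphenyl stood gives a number 90 percentage points lower from compound 1 to compound 3 (beyond the scatter), a second large step away from compound 1, and among these three compounds only the one with 4-hydroxyphenyl stands apart. No available evidence accounts for this difference.

Going by these compounds, it remains open whether the high reading depends on the hydroxy itself or on a group at that place on the ring, as 2-chlorophenyl differs from 4-hydroxyphenyl in both. A 4-methoxyphenyl, a 4-aminophenyl or a plain phenyl group on the same carbon would bear on that question.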